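From hydroxyphenyl to pyrrolyl on the imine carbon

A few compounds are considered here, and "the series" means these few. Any claim that something is new, unique, unknown or untested is made for them only; others in the source may bear on it.

Compound 2 `CC1=CC[C@H](C(C)(C)NC(=S)N/N=C/c2ccccc2O)CC1` is measured in a functional assay on PC-3 cells (Homo sapiens) for inhibition, read by sulforhodamine B assay, with a stated time of 48 h (on this read-out lower numbers stand for stronger inhibition of growth and higher numbers for weaker inhibition of growth), only as a limit, giving < 40 nM rather than a number. Compound 1 `CC1=CC[C@H](C(C)(C)N=C=S)CC1` likewise reaches only a limit there, at > 100000 nM. Compound 3 `CC1=CC[C@H](C(C)(C)NC(=S)N/N=C/c2ccccc2[N+](=O)[O-])CC1` gives a plain number, 1700 nM. Among the compounds with values here, the single measured step that involves compound 2 is an at least 42-fold higher number from compound 2 to compound 3 (1.62 log units; beyond the scatter), a move toward weaker growth inhibition. Compound 4 `CC1=CC[C@H](C(C)(C)NC(=S)N/N=C/c2ccc[nH]2)CC1` differs from compound 2 by 1H-pyrrol-2-yl in place of 2-hydroxyphenyl on a carbon with a double bond to nitrogen. Within the data shown here, no measured step replaces the whole ring, so the nearest guide is the step to compound 3, which altered one group on that same ring and lost much activity. Compound 4 is therefore expected to come in weaker than compound 2, at roughly 400 nM within 60 nM to 3000 nM, an estimated step of an at least 10-fold higher number from compound 2 to compound 4 (1.00 log units; beyond the scatter).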

Compound 4, concentration for 50% growth inhibition: 2800 nM
Compound 4: the middle estimate sits 7.0-fold (0.85 log units) below what was measured, and the stated range covers the measured number.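

Swapping the whole ring on the carbon with a double bond to nitrogen also weakens growth inhibition, with an at least 70-fold higher number from compound 2 to compound 4 (1.84 log units; beyond the scatter). So the loss seen earlier is not confined to changing one group on the 2-hydroxyphenyl ring. The 1H-pyrrol-2-yl group matches 2-hydroxyphenyl in its count of hydrogen-bond donors, so that count alone does not preserve activity here.

Going by these compounds, compound 2 is recorded only as a limit, so the true size of this step stays open: the limit of < 40 nM in this assay, at which 1 of the 4 values shown sits. How a plain phenyl or an aminophenyl group would fare on this carbon also remains open.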